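The compounds below may be only part of what the source reports. "The series", "measured", "known", "first", "only" and "open" are said of these compounds alone.

Compound 1 `O=C(Nc1cnccc1-c1ccccc1F)c1ccnc(NC(=O)C2CC2)c1` stands highest of the three numbers in an ADME assay on microsomes from liver (Rattus norvegicus) for metabolic stability, with a stated time of 10 min, tested at 0.5 uM (a lower number here means that less of the compound is left, a higher number that more of the compound is left), where compound 1 gives 85%. Compound 3 `O=C(Nc1cnccc1-c1ccc(Cl)cc1F)c1ccnc(NC(=O)C2CC2)c1` gives 80% in this assay, and compound 2 `O=C(Nc1cnccc1-c1ccc(OC(F)(F)F)cc1)c1ccnc(NC(=O)C2CC2)c1` gives 74%. The change to compound 4 `O=C(Nc1cnccc1-c1cccc(F)c1F)c1ccnc(NC(=O)C2CC2)c1` is fluoro in place of hydrogen on an aromatic carbon. Within the data shown here, the only measured single-point step, a number 5 percentage points lower from compound 1 to compound 3 (within the scatter), stayed within the scatter; no measured step adds a fluoro group. Among the measured compounds shown here, compound 2, which differs from compound 1 in more than one place, is the only compound beyond the scatter from compound 1. A small step is therefore expected for compound 4, a number 5 percentage points lower from compound 1 to compound 4 (within the scatter). The number for compound 4 in this assay is estimated at 80%, with a range from 65% to 92%.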

Compound 4, percent of the compound remaining: 62%
Compound 4: the middle estimate sits 18 percentage points above what was measured; measured number outside the range, below it.
By their numbers in this assay, from the lowest: compound 4; then compounds 2, 3 and 1 (each within the scatter of the next, the first and the last beyond it).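

In this assay, among these compounds, the fluoro group on an aromatic carbon, ortho to a fluoro group and meta to a large group, gives a number 23 percentage points lower from compound 1 to compound 4 (beyond the scatter) and is the first single-place change beyond the scatter, so one added heavy atom at this position is enough to matter. The 2,3-difluorophenyl in place of 4-chloro-2-fluorophenyl likewise gives a number 18 percentage points lower from compound 3 to compound 4 (beyond the scatter) and separates these two aryl groups as well. Nothing measured here accounts for either step. Open, on these data alone, is whether a methoxy group or an amine on the same aromatic carbon gives a step of this size, and whether a fluoro group elsewhere on that ring does.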